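A few compounds are considered here, and "the series" means these few. Any claim that something is new, unique, unknown or untested is made for them only; others in the source may bear on it.

Compound 1 `COCCCOc1cc(C)c(-c2cccc(COc3ccc(OCC(=O)O)c(F)c3)c2)c(C)c1` carries a 3-methoxypropoxy group on one ring of a shared core that is common to all four compounds described here. In a functional assay on CHO cells for agonist activity at Free fatty acid receptor 1 (Homo sapiens), read by FLIPR and calcium flux (a lower number here means that less compound is needed, a higher number that more compound is needed for the effect), compound 1 has no reported number, "not determined" (no result reported), so its standing cannot be placed on a scale; the same is true of compound 3 `Cc1cc(OCc2ccccc2)cc(C)c1-c1cccc(COc2ccc(OCC(=O)O)c(F)c2)c1`, which has no result either, "not determined" (no result reported). Going by the values given here, the only measured member of the set is compound 2 `CCOc1cc(C)c(-c2cccc(COc3ccc(OCC(=O)O)c(F)c3)c2)c(C)c1`, which carries an ethoxy group at the corresponding position. In this assay compound 2 gives 65.9 nM. Compound 4 `COc1cc(C)c(-c2cccc(COc3ccc(OCC(=O)O)c(F)c3)c2)c(C)c1` is the shortest member of the series and differs from compound 1 as follows: hydrogen in place of 2-methoxyethyl on a saturated chain carbon bound to an oxygen on an aromatic ring. Compound 4 is therefore the methoxy analogue, one carbon shorter in the alkoxy chain than compound 2. Among the compounds with values here, no step between compound 1 and compound 4 can be given, as compound 1 has no number. Judged from compound 2 alone, the change from a two-carbon to a one-carbon alkoxy chain is expected to stay within the usual scatter in this assay, with at most a modest drift toward a higher number. Compound 4 is estimated to give 110 nM in this assay, with a range from 35 nM to 350 nM.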

Compound 4, half-maximal effective concentration: 49.7 nM
Compound 4: middle estimate off by 2.2-fold (0.35 log units), on the high side, within the range that was stated.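

In this assay, going by these compounds alone, the change to hydrogen in place of methyl on a saturated chain carbon bound to an oxygen on an aromatic ring gives a 1.3-fold lower number from compound 2 to compound 4 (0.12 log units; within the scatter), the first step that can be read at this position. It shows that the ethoxy and methoxy compounds cannot be told apart in this read-out, so within this one pair the length of the short alkoxy chain leaves the number inside the scatter. Nothing among the available data bears on why the two compounds read alike.

Within the data shown here, compound 1 and compound 3 have no single number, so steps involving either cannot be read, and the pair of compound 2 and compound 4 remains the only comparison at this position. As far as these compounds go, what stays open is whether the number would hold with a longer plain chain such as propoxy or butoxy, or would shift with a hydroxyl or an amine at this position in place of the alkoxy group.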